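The compounds below may be only part of what the source reports. "The series", "measured", "known", "first", "only" and "open" are said of these compounds alone.

In a functional assay on MGC-803 cells (Homo sapiens) for inhibition, read by MTT assay, with a stated time of 48 h (a higher number here means a weaker inhibitor, a lower number a stronger inhibitor), compound 1 `Cc1ccc(NC(=S)NC(=O)c2ccc(OCc3cccc(C(F)(F)F)c3)cc2)cc1-c1nc2ccccc2[nH]1` gives 5210 nM. Compound 2 `Cc1ccc(NC(=S)NC(=O)c2ccc(OCc3cccc(Cl)c3Cl)cc2)cc1-c1nc2ccccc2[nH]1` reaches only the limit > 100000 nM in this assay, which is the limit of > 100000 nM in this assay, at which 1 of the 2 values shown sits. For the measured compounds named here, the single measured step, an at least 19-fold higher number from compound 1 to compound 2 (1.28 log units; beyond the scatter), is the only guide here. Compound 3 `Cc1ccc(NC(=S)NC(=O)c2ccc(OCc3cccc(F)c3)cc2)cc1-c1nc2ccccc2[nH]1` differs from compound 2 by 3-fluorophenyl in place of 2,3-dichlorophenyl on a saturated chain carbon bound to an oxygen on an aromatic ring. A ring carrying one substituent, as in compound 1 at 5210 nM, is expected to bring the number back down. The step of an at least 10-fold lower number from compound 2 to compound 3 (1.00 log units; beyond the scatter) is the expected size of that return. Compound 3 is therefore estimated at 10000 nM, within 3000 nM to 60000 nM.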

Compound 3, half-maximal inhibitory concentration: > 100000 nM
Compound 3 was reported as a limit; the forecaster's own chance of this, stated with the estimate: 25%; middle value at least 10-fold (1.00 log units) from the limit.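

A single fluoro substituent does not restore a readable value at this position: fluoro in place of trifluoromethyl on an aromatic carbon gives an at least 19-fold higher number from compound 1 to compound 3 (1.28 log units; beyond the scatter). Of the three rings, only the 3-(trifluoromethyl)phenyl of compound 1 gives a readable value, and the step from compound 2 to compound 3 cannot be read, both values being limits. Readings at this position are now mostly capped: the limit of > 100000 nM in this assay, at which 2 of the 3 values shown sit.

Still open, going by these compounds, is whether anything other than trifluoromethyl gives a readable value here. A 3-chlorophenyl, 3-methoxyphenyl or unsubstituted phenyl ring would test this.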